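The compounds below may be only part of what the source reports. "The series", "measured", "known", "first", "only" and "open" are said of these compounds alone.

In a functional assay on HepG2 cells (Homo sapiens) for inhibition, read by MTT assay, with a stated time of 24 h (a higher number here means a weaker inhibitor, a lower number a stronger inhibitor), compound 1 (`COc1ccc(/C=N/NC(=O)CNC(=O)c2ccc(F)cc2)c(OCc2ccccc2Cl)c1`) gives 15700 nM. Compound 2 (`CCN(CC)c1ccc(/C=N/NC(=O)CNC(=O)c2ccc(F)cc2)c(OCc2ccccc2Cl)c1`) reads > 50000 nM, which is a limit of the assay and not a number. Compound 3 (`CCN(CC)c1ccc(/C=N/NC(=O)CNC(=O)c2ccc(C#N)cc2)c(OCc2ccccc2Cl)c1`) reads > 50000 nM, which is likewise only a limit. On these data alone, compound 3 thus stands at the limit of > 50000 nM in this assay, at which 2 of the 3 values shown sit, and its true position is unknown.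

Compound 4 (`COc1ccc(/C=N/NC(=O)CNC(=O)c2ccc(C#N)cc2)c(OCc2ccccc2Cl)c1`) differs from compound 3 by a single exchange, methoxy in place of diethylamino on an aromatic carbon. Within the data shown here, two measured steps bear on this change. The opposite exchange, made with fluoro in the place of cyano, gave an at least 3.1-fold higher number from compound 1 to compound 2 (0.50 log units; beyond the scatter). The exchange of fluoro for cyano gave a step that the two limits leave unreadable from compound 2 to compound 3, so the data do not show how far cyano itself moves the number.

Compound 4 is therefore expected to return to a lower number in this assay, in the region of compound 1 at 15700 nM, though with wide uncertainty. The estimate amounts to an at least 2.9-fold lower number from compound 3 to compound 4 (0.46 log units; beyond the scatter). For compound 4 the expected value is 17000 nM, with an estimated range of 6000 nM to 45000 nM.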

Compound 4, half-maximal inhibitory concentration: > 50000 nM
Compound 4 ended at the assay's limit; the forecaster's own chance of this, stated with the estimate: 20%; middle value at least 2.9-fold (0.46 log units) away from the limit.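

In this assay, the exchange of fluoro for cyano can now be read with methoxy held in place, and it gives an at least 3.1-fold higher number from compound 1 to compound 4 (0.50 log units; beyond the scatter). Compound 4 reads > 50000 nM, which is a limit of the assay and not a number, so methoxy on this carbon does not by itself bring a cyano compound to a measured value. The steps from compound 2 to compound 3 and from compound 3 to compound 4 cannot be read, which leaves the exchange of methoxy and diethylamino with a readable size only in the fluoro pair, and the series now gathers at one limit: the limit of > 50000 nM in this assay, at which 3 of the 4 values shown sit.

Compound 1, at 15700 nM, remains the only compound shown with a measured number. On these data alone, how far compound 2, compound 3 and compound 4 lie past the limit stays unknown. Also open, as far as these compounds go, is whether a chloro or a trifluoromethyl group in place of the cyano, or an ethoxy group in place of the methoxy, would give a measured number in this assay.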